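The compounds below may be only part of what the source reports. "The series", "measured", "known", "first", "only" and "open" are said of these compounds alone.

In a functional assay on cells (Homo sapiens) for cytotoxicity (a higher number here means that more compound is tolerated, a lower number that less compound is tolerated), compound 1 `O=C1N(CCCCCCOc2ccc(Br)cc2)CCN1c1ccnc(Cl)c1` reaches only a limit of the assay, > 25000 nM. Compound 2 `O=C1N(CCCCCCOc2ccc(Br)cc2)CCN1c1ccncn1` likewise stops at a limit, > 25000 nM. The step that the two limits leave unreadable from compound 1 to compound 2 therefore cannot be read, and the limit of > 25000 nM in this assay, at which 2 of the 2 values shown sit, leaves compound 2 standing at that same limit, with no number of its own. Compound 3 `O=C1N(CCCCCCOc2ccc(Br)cc2)CCN1c1ccccc1` differs from compound 2 in one place: phenyl in place of pyrimidin-4-yl on an amide-type nitrogen in a ring. Within the data shown here, only that unreadable step bears on this exchange, so the step expected is a step that the limit leaves unreadable from compound 2 to compound 3, none beyond the scatter. Compound 3 is accordingly estimated at 40000 nM, within a range from 20000 nM to 100000 nM, most likely again reported only as a limit.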

Compound 3, half-maximal cytotoxic concentration: > 25000 nM
Compound 3: no number, only a limit; the forecaster's own chance of this, stated with the estimate: 80%; the middle value is on the limit's open side.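

Compound 1, compound 2 and compound 3 all stop at a limit in this assay, so no step among them can be read: the limit of > 25000 nM in this assay, at which 3 of the 3 values shown sit.

The compounds shown leave open whether exchanging the group on the amide-type nitrogen changes cytotoxicity at all.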